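The source may report more compounds than this note shows. Statements on the series, on what has been measured and on what is new or still open speak of the compounds shown alone.

Compound 1 `COc1ccc(OC)c(/C=C/c2nnc(Nc3ccc(Cl)cc3)o2)c1` and compound 2 `COc1ccc(OC)c(/C=C/C(=O)N/N=C/c2ccc(Cl)cc2)c1` share the same left-hand core and part company in the middle of the molecule. In a functional assay on MDA-MB-468 cells (Homo sapiens) for antiproliferative activity, read by sulforhodamine B assay, with a stated time of 48 h (a higher number here means a weaker inhibitor of growth, a lower number a stronger inhibitor of growth), compound 1 gives only a limit of the assay, > 100000 nM. In this assay compound 2 gives 445 nM. Among the compounds with values here, that is the only number among the two values shown; the other entry is a limit (the limit of > 100000 nM in this assay, at which 1 of the 2 values shown sits), so compound 2 stands alone as the sole quantified inhibitor of growth in the set. Compound 3 `COc1ccc(OC)c(/C=C/C(=O)N/N=C/c2ccccc2)c1` is not yet measured. It differs from compound 2 by hydrogen in place of chloro on an aromatic carbon, the chloro having sat para to a large group. Within the data shown here, no step between two measured compounds exists against which this change can be gauged. The expected step from compound 2 to compound 3, a 2.5-fold higher number from compound 2 to compound 3 (0.39 log units; beyond the scatter), is a modest loss of growth inhibition, of a size only just beyond the scatter. Compound 3 is accordingly estimated at 1100 nM, with a range from 300 nM to 4500 nM.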

Compound 3, concentration for total growth inhibition: 6470 nM
The estimate for compound 3 lay 5.9-fold (0.77 log units) below the measured number; measured number above the stated range.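

With compound 3, the series has its first step between two measured compounds, and it isolates the contribution of this single position. Replacing the chloro, para to a large group, with hydrogen gives a 15-fold higher number from compound 2 to compound 3 (1.16 log units; beyond the scatter) in this assay, so the change from 4-chlorophenyl to phenyl is a large one and not a minor adjustment at this end of the molecule. Growth inhibition is weakened without being lost, since compound 3 still gives a measured number, 6470 nM. Nothing measured here bears on why the chloro has so large an effect. From the compounds shown here alone, whether this effect is specific to chlorine remains open, as a fluoro, bromo, methyl or methoxy group at the same place would be needed to tell.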